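A few compounds are considered here, and "the series" means these few. Any claim that something is new, unique, unknown or untested is made for them only; others in the source may bear on it.

Working notes on the series.

Compound 1 `CNc1nc(-c2cc(OC)c(OC)c(OC)c2)c(-c2ccc(C)cc2)s1` gives 18.1 nM in a functional assay on HL-60 cells (Homo sapiens) for antiproliferative activity, read by MTT assay, with a stated time of 72 h; on this read-out higher numbers stand for weaker inhibition and lower numbers for stronger inhibition. Compound 2 `CNc1nc(-c2cc(OC)c(OC)c(OC)c2)c(-c2ccc(OC)cc2)s1` gives 27.3 nM in this assay, and the step of a 1.5-fold higher number from compound 1 to compound 2 (0.18 log units; within the scatter) is within the scatter. Compound 3 `COc1cc(-c2nc(N(C)C)sc2-c2ccc(C)cc2)cc(OC)c1OC` gives 3480 nM in this assay; the step of a 190-fold higher number from compound 1 to compound 3 (2.28 log units; beyond the scatter) is the one large movement recorded so far, and compound 3 stands highest of the three numbers measured, with compound 2 nearest to it and compound 1 furthest from it.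

Compound 4 `COc1ccc(-c2sc(N(C)C)nc2-c2cc(OC)c(OC)c(OC)c2)cc1` has not been measured. It differs from compound 3 in one place: methoxy in place of methyl on an aromatic carbon.

Among the compounds with values here, the only measured step that bears on this change is a 1.5-fold higher number from compound 1 to compound 2 (0.18 log units; within the scatter), where the same exchange of methoxy for methyl on the aromatic carbon was made on a core carrying the hydrogen on the ring nitrogen rather than the second methyl. That step stayed within the scatter. On that basis the expected step of a 1.3-fold higher number from compound 3 to compound 4 (0.11 log units; within the scatter) is none beyond the scatter, and compound 4 is estimated at 4500 nM, with a range from 1800 nM to 11000 nM.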

Compound 4, half-maximal inhibitory concentration: 1890 nM
Beside the measured number, compound 4's estimate is 2.4-fold (0.38 log units) above it; the range from low to high includes it.
By their numbers in this assay, from the lowest: compounds 1 and 2 (each within the scatter of the next); then compounds 4 and 3 (each within the scatter of the next).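

In this assay, the exchange of methoxy for methyl on the aromatic carbon, 4-methylphenyl to 4-methoxyphenyl, also stays within the scatter on the core of compound 3, at a 1.8-fold lower number from compound 3 to compound 4 (0.27 log units; within the scatter), though the steps on the two cores do not run the same way and the gap between them lies beyond the scatter: the same change on two cores in this assay, a 1.5-fold higher number (0.18 log units; within the scatter) from compound 1 to compound 2 and a 1.8-fold lower number (0.27 log units; within the scatter) from compound 3 to compound 4, 2.8-fold (0.44 log units) apart, beyond the scatter of two such steps

The methyl in place of hydrogen on the nitrogen remains a large movement with 4-methoxyphenyl in place, at a 69-fold higher number from compound 2 to compound 4 (1.84 log units; beyond the scatter), so it is not confined to the compounds carrying 4-methylphenyl. Its size still differs between the two pairs: the same change on two cores in this assay, a 190-fold higher number (2.28 log units; beyond the scatter) from compound 1 to compound 3 and a 69-fold higher number (1.84 log units; beyond the scatter) from compound 2 to compound 4, 2.8-fold (0.44 log units) apart, beyond the scatter of two such steps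

The compounds shown leave open how a chlorine, a hydroxyl or an amine at this aromatic carbon would read on either core. They also leave open how an ethyl group or a longer chain on the nitrogen would compare with the methyl.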